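A Shorter Side Chain on the Shared Core

The source may report more compounds than this note shows. Statements on the series, on what has been measured and on what is new or still open speak of the compounds shown alone.

Compound 1 `COC(CCn1cnc2c(NCc3ccc(C(=O)Nc4ccccc4N)cc3)nc(Cl)nc21)OC`: 11.9%
Compound 2 `Cc1ccc(Nc2nc(Cl)nc3c2ncn3Cc2ccc(C(=O)Nc3ccccc3N)cc2)cc1`: 81.5%
Compound 3 `Cc1ccc(Nc2nc(Cl)nc3c2ncn3Cc2ccc(/C=C/C(=O)Nc3ccccc3N)cc2)cc1`: 15%

In a functional assay on HCT-116 cells (Homo sapiens) for antiproliferative activity, read by CCK-8 assay, with a stated time of 72 h, tested at 8 uM (on this read-out higher numbers stand for a stronger effect at the one concentration tested and lower numbers for a weaker effect), compound 1 gives the lowest of the three numbers; compound 3 sits within the scatter of it, while compound 2 lies far beyond it. Going by the values given here, the only measured step, a number 66.5 percentage points lower from compound 2 to compound 3 (beyond the scatter), concerns a different part of the molecule and therefore says nothing direct about the side chain. Compound 4 `CCCCn1cnc2c(NCc3ccc(C(=O)Nc4ccccc4N)cc3)nc(Cl)nc21` differs from compound 1 by ethyl in place of dimethoxymethyl on a saturated chain carbon, two bonds along the chain from an aromatic nitrogen. Among the compounds with values here, no measured step touches this chain, so nothing in the data argues for a move beyond the scatter in this assay. Compound 4 is therefore expected at 15%, with a range of 3% to 35%. That estimate corresponds to an expected a number 3.1 percentage points higher from compound 1 to compound 4 (within the scatter), within the scatter.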

Compound 4, a percentage reported as inhibition, at one concentration (the size of the read-out at that concentration, not a potency): 40.9%
For compound 4 the middle estimate is 25.9 percentage points below the measured one; measured number above the stated range.
By their numbers in this assay, from the lowest: compounds 1 and 3 (each within the scatter of the next); then compound 4; then compound 2.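

In this assay, going by these compounds alone, the change from dimethoxymethyl to ethyl gives a number 29 percentage points higher from compound 1 to compound 4 (beyond the scatter) and shows that this side chain position is not silent, which no earlier step could show. Read one bond further out, 3,3-dimethoxypropyl gives way to butyl, so the chain end loses both oxygen atoms and the effect at this position can be seen on the shared core. No available evidence explains the change. Whether the oxygen atoms or the size of the chain end accounts for the difference stays open. So does how a longer alkyl chain, a hydroxyl or an amine at this chain end would read.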